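The compounds below may be only part of what the source reports. "The series", "measured", "known", "first", "only" and "open" are said of these compounds alone.

compound 1 `CC(C)(C)C#Cc1cc(N(C(=O)[C@H]2CC[C@H](C)CC2)[C@H]2CC[C@H](Oc3cccnc3)CC2)c(C(=O)O)s1`: > 20000 nM (a limit)
compound 2 `CC(C)(C)C#Cc1cc(N(C(=O)[C@H]2CC[C@H](C)CC2)[C@H]2C[C@@H](Oc3cccnc3)C2)c(C(=O)O)s1`: > 20000 nM (a limit)

Both entries come from an ADME assay on MT4 cells (Homo sapiens) for cytotoxicity, with a stated time of 5 days (on this read-out lower numbers stand for higher toxicity in this test and higher numbers for lower toxicity in this test), and neither is a number. Among the measured compounds shown here, compound 2 stands on a limit and compound 1 stands on the same one, so the series so far reads as the limit of > 20000 nM in this assay, at which 2 of the 2 values shown sit, and gives no measured step.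

The next entry is compound 3 `CC(C)(C)C#Cc1cc(N(C(=O)[C@H]2CC[C@H](C)CC2)[C@H]2CC[C@H](Oc3nccs3)CC2)c(C(=O)O)s1`. The change is 4-((1,3-thiazol-2-yl)oxy)cyclohexyl in place of 3-((pyridin-3-yl)oxy)cyclobutyl on an amide-type nitrogen.

No step beyond the usual scatter, in either direction, is expected in this assay. The estimated step is a step that the limit leaves unreadable from compound 2 to compound 3 in this read-out. That expectation rests on compound 2 , whose limit is > 20000 nM and no more than that. For compound 3 the estimate is 22000 nM, with an expected range from 11000 nM to 40000 nM and another limit as the likelier report.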

Compound 3, half-maximal cytotoxic concentration: > 20000 nM
Compound 3: only a limit was reported; the forecaster's own chance of this, stated with the estimate: 85%; the middle value lies beyond the limit too.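

In this assay, among the compounds shown here, compound 3 gives > 20000 nM, a limit and not a number, so no step from compound 1 or compound 2 to compound 3 can be read. The compounds shown leave open which structural change, if any, would yield a measured value rather than a limit: the limit of > 20000 nM in this assay, at which 3 of the 3 values shown sit.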